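A few compounds are considered here, and "the series" means these few. Any claim that something is new, unique, unknown or untested is made for them only; others in the source may bear on it.

Measured so far:
- compound 1, `COCCNC(=O)CCNc1ncc2c(Br)nn(-c3ccc4ncccc4c3)c2n1`
- compound 2, `CS(=O)(=O)N1CC[C@@H](Nc2ncc3c(Br)nn(-c4ccc5ncccc5c4)c3n2)C1`
- compound 3, `CNC(=O)[C@@H]1CC[C@@H](Nc2ncc3c(Br)nn(-c4ccc5ncccc5c4)c3n2)C1`

In an assay on isolated protein for inhibition of eIF-2-alpha kinase GCN2 (Homo sapiens) (on this read-out lower numbers stand for stronger inhibition and higher numbers for weaker inhibition), compound 1 gives only a limit, > 1000 nM (the limit of > 1000 nM in this assay, at which 1 of the 3 values shown sits). In this assay compound 2 gives 90 nM and compound 3 gives 21 nM; compound 3 stands lowest of the two numbers, with a 4.3-fold lower number from compound 2 to compound 3 (0.63 log units; beyond the scatter) and an at least 47-fold lower number from compound 1 to compound 3 (1.67 log units; beyond the scatter).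

Compound 4, `CNC(=O)[C@]1(C)CC[C@@H](Nc2ncc3c(Br)nn(-c4ccc5ncccc5c4)c3n2)C1`, differs from compound 3 only in one place: a group of 10 heavy atoms (8 carbon, 1 nitrogen, 1 oxygen; one five-membered non-aromatic ring of carbon only) in place of a group of 9 heavy atoms (7 carbon, 1 nitrogen, 1 oxygen; one five-membered non-aromatic ring of carbon only), on a nitrogen on an aromatic ring. Both measured steps into compound 3 exchange the whole group on that nitrogen, whereas here the five-membered ring and its carbamoyl are kept and the group grows by a small addition. Going by the values given here, no measured step tests such an addition, so no change beyond the scatter is expected, a 1.2-fold higher number from compound 3 to compound 4 (0.08 log units; within the scatter). Compound 4 is estimated at 25 nM in this assay, with a range of 8 nM to 80 nM.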

Compound 4, half-maximal inhibitory concentration: 17 nM
Beside the measured number, compound 4's estimate is 1.5-fold (0.17 log units) above it, within the range that was stated.
By their numbers in this assay, from the lowest: compounds 4 and 3 (each within the scatter of the next); then compound 2. At a limit, above all of these: compound 1.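

Within the five-membered carbon ring groups on the aromatic nitrogen, a small addition is tolerated in this assay (a 1.2-fold lower number from compound 3 to compound 4 (0.09 log units; within the scatter)). The larger group of compound 4 also keeps its margin over the methylsulfonyl pyrrolidine group (a 5.3-fold lower number from compound 2 to compound 4 (0.72 log units; beyond the scatter)). The margin over the open-chain group is large (an at least 58-fold lower number from compound 1 to compound 4 (1.76 log units; beyond the scatter)), but it is only a bound, since compound 1 gives a limit: the limit of > 1000 nM in this assay, at which 1 of the 4 values shown sits.

Going by these compounds, whether a larger addition, such as a longer chain or a phenyl, is accepted remains open. Also open, on these data alone, is whether an amine or a carboxylic acid can replace the carbamoyl.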